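Three pyrazole chalcones and a difluorophenyl analogue in melanoma cells

The source may report more compounds than this note shows. Statements on the series, on what has been measured and on what is new or still open speak of the compounds shown alone.

Measured compounds:
- compound 1, `COc1cc(-c2cc(/C=C/C(=O)c3ccc(N)cc3)[nH]n2)cc(OC)c1OC`, 93%
- compound 2, `COc1ccc(-c2cc(/C=C/C(=O)c3ccc(OC)c(OC)c3)[nH]n2)cc1`, 86%
- compound 3, `COc1ccc(-c2cc(/C=C/C(=O)c3cc(OC)c(OC)c(OC)c3)[nH]n2)cc1OC`, 97%

In a functional assay on UACC-257 cells (Homo sapiens) for cytotoxicity, read by sulforhodamine B assay, with a stated time of 48 h, tested at 0.1 uM (on this read-out higher numbers stand for a weaker effect at the one concentration tested and lower numbers for a stronger effect), compound 1 gives 93%, which is the second highest of the three numbers. Its nearest neighbour is compound 3, whose value in this assay is 97%; the gap between the two lies within the scatter. The furthest is compound 2 with 86% in this assay, and that gap also lies within the scatter. The three compounds thus cannot be ranked against one another on these numbers.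

Compound 4, `COc1cc(-c2cc(/C=C/C(=O)c3ccc(F)c(F)c3)[nH]n2)cc(OC)c1OC`, has not yet been measured in this assay. It differs from compound 1 in one place:

3,4-difluorophenyl in place of 4-aminophenyl on a carbonyl carbon

Going by the values given here, no step between two measured compounds is available for this change. Since the three measured values all sit within the scatter of one another, the expectation for compound 4 is a step of no size beyond the scatter in either direction, a number 1 percentage points lower from compound 1 to compound 4 (within the scatter). Compound 4 is therefore estimated at 92% in this assay, with a range from 80% to 104%.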

Compound 4, a percentage reported as activity, at one concentration (the size of the read-out at that concentration, not a potency): 92%
Compound 4: middle estimate and measured number agree at the digits printed, within the range that was stated.
By their numbers in this assay, from the lowest: compounds 2, 4, 1 and 3 (each within the scatter of the next, the first and the last beyond it).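

Going by these compounds alone, putting 3,4-difluorophenyl in place of 4-aminophenyl on the carbonyl carbon gives a number 1 percentage points lower from compound 1 to compound 4 (within the scatter) in this assay and is the first step that can be read at a single place. The change takes away the hydrogen-bond donor and acceptor counted on the 4-aminophenyl group and brings in two fluorine atoms, yet the read-out at this position stays within the scatter, so this exchange leaves no visible mark at the one concentration tested. Nothing available here bears on why the two compounds read alike.

On these data alone, whether a carboxylic acid, a hydroxyl group or a morpholine ring on the same carbonyl carbon would read any differently remains open. So does the question of whether compound 1 and compound 4 would still read alike at a higher concentration.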